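From an Ethyl to a Tert-Butyl Group

The source may report more compounds than this note shows. Statements on the series, on what has been measured and on what is new or still open speak of the compounds shown alone.

For the measured compounds named here, compound 1 `COc1ccc(OC(=O)c2cn(-c3ccccc3)nc2-c2ccncc2)cc1` is the only compound here with a reported value. In a functional assay on HL-60 cells (Homo sapiens) for cytotoxicity, read by MTT assay, with a stated time of 48 h (a higher number here means a weaker inhibitor, a lower number a stronger inhibitor), compound 1 gives > 100000 nM, which is a limit of the measurement rather than a number. Compound 2 `CCc1ccc(OC(=O)c2cn(-c3ccccc3)nc2-c2ccncc2)cc1` shares the same core with a different group on the outer ring. In this assay compound 2 gives "nd(insoluble)" (no result reported), so no result was obtained for it. Going by the values given here, compound 2 therefore has no number of its own to stand on, and the only other value shown is the limit of > 100000 nM in this assay, at which 1 of the 2 values shown sits. Compound 3 `CC(C)(C)c1ccc(OC(=O)c2cn(-c3ccccc3)nc2-c2ccncc2)cc1` is not yet measured; it differs from compound 2 by tert-butyl in place of ethyl on an aromatic carbon. Among the compounds with values here, with no measured step available, no direction beyond the scatter can be stated. Compound 3 is expected to give about 100000 nM, within a range from 30000 nM to 300000 nM, most likely reported again only as a limit.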

Compound 3, half-maximal inhibitory concentration: 18700 nM
The estimate for compound 3 lay 5.3-fold (0.73 log units) above the measured number; measured number outside the range, below it.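

Compound 3 shows that the position para to a large group on the six-membered aromatic ring can carry a group that gives a real number in this assay: compound 3 gives 18700 nM, the only number among the compounds shown. Replacing methoxy with tert-butyl at this position gives an at least 5.3-fold lower number from compound 1 to compound 3 (0.72 log units; beyond the scatter). From the compounds shown here alone, compound 1 gives > 100000 nM, which is a limit and not a number, so the full size of that step remains unknown.

Compound 2 has no result and its step to compound 3 cannot be read; nothing shown gives a reason for the change from methoxy to tert-butyl. Also open, going by these compounds, is how an amine, a carboxylic acid or a longer chain at this position would read in this assay.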